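Mirror-image piperazine on the dimethyl benzimidazole core

The compounds below may be only part of what the source reports. "The series", "measured", "known", "first", "only" and "open" are said of these compounds alone.

Measured so far:
compound 1, `CC(C)(C)c1ccc2[nH]c(N3CCN(c4ncccc4Cl)CC3)nc2c1`, 1690 nM
compound 2, `C[C@@H]1CN(c2ncccc2Cl)CCN1c1nc2ccc(C(C)(C)C)cc2[nH]1`, 104 nM
compound 3, `Cc1cc2nc(N3CCN(c4ncccc4Cl)C[C@H]3C)[nH]c2cc1C`, 10000 nM

In a functional assay on HEK293 cells for antagonist activity at transient receptor potential cation channel subfamily V member 1 (Homo sapiens), read by FLIPR, at pH 5.5 (a lower number here means a stronger inhibitor, a higher number a weaker inhibitor), compound 3 gives the highest number of the three, the weakest inhibitor. Its nearest neighbour is compound 1, whose number is lower by a margin beyond the scatter, and the furthest is compound 2, whose number is lower by a much wider margin.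

Compound 4, `Cc1cc2nc(N3CCN(c4ncccc4Cl)C[C@@H]3C)[nH]c2cc1C`, is the mirror image of compound 3 at its one stereocentre: the two compounds have the same atoms and bonds and differ only in configuration as drawn: 1 of 1 stereo elements differ; a stereocentre at a saturated ring carbon is drawn R in compound 3 and S in compound 4. Nothing is added and nothing is removed; only the handedness of the methyl-bearing ring carbon changes.

Going by the values given here, there is no measured pair in this set that differs only in that way, so the size of the step is uncertain. What the numbers do show is that a methyl-bearing piperazine can reach 104 nM in compound 2, on a different core, while compound 3 sits at the top of the range. A meaningful drop is therefore expected for compound 4, though with a wide band because the core of compound 2 is not the core of compound 3.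

Compound 4 is expected to give 1500 nM in this assay, between 300 nM and 8000 nM, a step of a 6.7-fold lower number from compound 3 to compound 4 (0.82 log units; beyond the scatter).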

Compound 4, half-maximal inhibitory concentration: > 25000 nM
Compound 4: no number, only a limit; the forecaster's own chance of this, stated with the estimate: 15%; middle value at least 16-fold (1.22 log units) from the limit.
By their numbers in this assay, from the lowest: compound 2; then compound 1; then compound 3. At a limit, above all of these: compound 4.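

In this assay, the mirror-image swap alone gives an at least 2.5-fold higher number from compound 3 to compound 4 (0.39 log units; beyond the scatter), which shows that the handedness of the methyl-bearing ring carbon matters on this core, even though no atom is added or removed. Compound 4 gives > 25000 nM, which is a limit of the assay and not a number, so the printed step is only the smallest gap the data allow, and the true gap could be wider. The shift can be put down to configuration alone, since nothing else separates the two compounds: the fact that compounds 3 and 4 differ only in the configuration as drawn.

From the compounds shown here alone, whether the same handedness is favoured on the other core remains open, and the mirror image of compound 2 would settle that directly, with compound 1 showing the same core without the methyl group. Also open, going by these compounds, are how the dimethyl core behaves with no methyl group on the piperazine at all, and whether an ethyl or a hydroxymethyl group at the same ring carbon would show the same dependence on handedness.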